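The compounds below may be only part of what the source reports. "The series", "measured", "known", "first", "only" and "open" are said of these compounds alone.

Compounds measured in a functional assay on HeLa cells (Homo sapiens) for inhibition, read by MTT assay, with a stated time of 72 h; on this read-out lower numbers stand for stronger inhibition and higher numbers for weaker inhibition: compound 1 `CN(C(=O)NC(=O)c1ccc(F)c(F)c1)c1nc(C(F)(F)F)c(C(=O)N/N=C/c2ccc(C(F)(F)F)cc2)s1` gives 5.1 ug/mL; compound 2 `CN(C(=O)NC(=O)c1ccc(Cl)cc1Cl)c1nc(C(F)(F)F)c(C(=O)N/N=C/c2ccc(C(F)(F)F)cc2)s1` gives 7.99 ug/mL. For compound 3 `CN(C(=O)NC(=O)c1ccc(C(F)(F)F)cc1)c1nc(C(F)(F)F)c(C(=O)N/N=C/c2ccc(C(F)(F)F)cc2)s1` the assay returns only a limit, > 100 ug/mL.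

Compound 1 and compound 2 lie within the usual scatter of each other, with a 1.6-fold higher number from compound 1 to compound 2 (0.19 log units; within the scatter). Both steps to compound 3, an at least 19-fold higher number from compound 1 to compound 3 (1.29 log units; beyond the scatter) and an at least 12-fold higher number from compound 2 to compound 3 (1.09 log units; beyond the scatter), are large and reach (the limit of > 100 ug/mL in this assay, at which 1 of the 3 values shown sits). Compound 4 `CN(C(=O)NC(=O)c1ccc(F)c(F)c1)c1nc(C(F)(F)F)c(C(=O)N/N=C/c2ccc([N+](=O)[O-])cc2)s1` differs from compound 1 by nitro in place of trifluoromethyl on an aromatic carbon. The measured steps all change the aryl group on a carbonyl carbon, so none bears directly on this change, and no step beyond the scatter is expected in this assay. Compound 4 is therefore estimated at 5.5 ug/mL (2 ug/mL to 15 ug/mL), a step of a 1.1-fold higher number from compound 1 to compound 4 (0.03 log units; within the scatter).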

Compound 4, half-maximal inhibitory concentration: 5.08 ug/mL
Estimate against measurement, compound 4: 1.1-fold (0.03 log units) above, within the range that was stated.
By their numbers in this assay, from the lowest: compounds 4, 1 and 2 (each within the scatter of the next). At a limit, above all of these: compound 3.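

At this position, on an aromatic carbon para to a large group, nitro in place of trifluoromethyl moves this assay by no more than the scatter, with a 1.0-fold lower number from compound 1 to compound 4 (0.00 log units; within the scatter). Among these compounds, the earlier steps all changed the aryl group on a carbonyl carbon, so this is the first reading at this position, and hydrogen-bond acceptors enter here without a step beyond the scatter. Nothing measured here gives a reason for this result. The compounds shown leave open how an amine or a carboxylic acid would read at this position. They also leave open whether nitro gives the same reading when 3,4-difluorophenyl is replaced.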